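The source may hold more compounds than are shown below. What is called first, only, known or untested is meant among the compounds shown, and "the series" means these compounds.

Measured compounds:
compound 1 `O=C(S[C@]12CC[C@H](O)[C@H]1C(=O)NC2=O)c1ccccc1Cl` with 717000 nM in an ADME assay on RAW264.7 cells (Mus musculus) for cytotoxicity, read by MTT assay, with a stated time of 24 h; on this read-out lower numbers stand for stronger inhibition and higher numbers for weaker inhibition
compound 2 `O=C(S[C@]12CC[C@H](O)[C@H]1C(=O)NC2=O)c1ccccc1` with 17100000 nM in this assay
compound 3 `CC(=O)OC1CC[C@]2(SC(=O)c3ccccc3Cl)C(=O)NC(=O)[C@H]12` with 9080000 nM in this assay

Compound 4 `CC(=O)OC1CC[C@]2(SC(=O)c3ccccc3)C(=O)NC(=O)[C@H]12` remains to be measured in this assay.

The change from compound 1 to compound 2 is hydrogen in place of chloro on an aromatic carbon. It gave a 24-fold higher number from compound 1 to compound 2 (1.38 log units; beyond the scatter). The change from compound 3 to compound 4 is hydrogen in place of chloro on an aromatic carbon. The two places read the same word for word, so this is the same change made on a different core; the difference between the core of compound 1 and the core of compound 3 is not broken down here.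

Compound 3 already stands near compound 2, within the usual scatter of that pair, and well above compound 1. Among the measured compounds shown here, since the only precedent for this change is the large upward step from compound 1 to compound 2, a step of the same direction is expected from compound 3 to compound 4, though with the number already so high it is plausible that this assay will report only a limit. For compound 4 the expected step is a 5.5-fold higher number from compound 3 to compound 4 (0.74 log units; beyond the scatter). For compound 4 the estimate in this assay is 50000000 nM, with a range from 15000000 nM to 200000000 nM.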

Compound 4, half-maximal inhibitory concentration: 1910000 nM
For compound 4 the middle estimate is 26-fold (1.42 log units) above the measured one; the whole stated range lies above it.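

In this assay, hydrogen in place of chloro on the core of compound 3 gives a 4.8-fold lower number from compound 3 to compound 4 (0.68 log units; beyond the scatter), so the change does not carry over from one core to the other, in size or in direction: the same change on two cores in this assay, a 24-fold higher number (1.38 log units; beyond the scatter) from compound 1 to compound 2 and a 4.8-fold lower number (0.68 log units; beyond the scatter) from compound 3 to compound 4, 110-fold (2.05 log units) apart, beyond the scatter of two such steps The step from 2-chlorophenyl to phenyl therefore cannot be treated as having one fixed effect on this read-out across the series, and a value on one of these cores cannot be predicted from the step on the other. The data do not show which part of the difference between the core of compound 1 and the core of compound 3 goes with the reversal, and two pairs give no general rule.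

As far as these compounds go, it remains open how fluoro, bromo or an amine in place of chloro on that aromatic carbon would behave on either core. Also open, from the compounds shown here alone, is whether the lower number on going to phenyl would persist with a longer chain in place of the acetyl group of compound 3.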